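Trimming the chain on the aromatic oxygen

This account rests on a few compounds, and the source may have more. Where it says the series, first, only, none or still open, it means among the compounds named here.

Among the measured compounds shown here, in a functional assay on NCI-H1650 cells (Homo sapiens) for cytotoxicity, read by MTT assay, with a stated time of 48 h (on this read-out higher numbers stand for weaker inhibition and lower numbers for stronger inhibition), compound 1 `CCCCCCCCOc1ccc2c(Cl)ccnc2c1` gives 3240 nM and compound 2 `CCCCCCOc1ccc2c(Cl)ccnc2c1` gives 2080 nM; the step of a 1.6-fold lower number from compound 1 to compound 2 (0.19 log units; within the scatter) leaves the two within the scatter of each other, so compound 2 stands level with its only neighbour. Compound 3 `C=CCOc1ccc2c(Cl)ccnc2c1` carries vinyl in place of pentyl on a saturated chain carbon bound to an oxygen on an aromatic ring, a larger cut along the same chain. The step from compound 1 to compound 2 is the only one that bears on it, and it stayed within the scatter, so no step beyond the scatter in this assay is expected, with a wider range to allow for the deeper cut. Compound 3 is estimated at 2500 nM (range 900 nM to 7000 nM), which is expected to amount to a 1.2-fold higher number from compound 2 to compound 3 (0.08 log units; within the scatter).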

Compound 3, half-maximal inhibitory concentration: 2280 nM
The estimate for compound 3 lay 1.1-fold (0.04 log units) above the measured number; the measured number falls inside the stated range.
By their numbers in this assay, from the lowest: compounds 2, 3 and 1 (each within the scatter of the next).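

In this assay the exchange of pentyl for vinyl gives a 1.1-fold higher number from compound 2 to compound 3 (0.04 log units; within the scatter), so the deeper cut from hexyl to allyl, which also brings in a double bond outside aromatic rings, still leaves the numbers level. Across the compounds shown, this place on the chain therefore tolerates a wider range of chain lengths than the first step alone could show. Nothing measured here explains this flat response. Still open, as far as these compounds go, is whether an amine or a carboxylic acid on the chain would give a step beyond the scatter. From the compounds shown here alone, the effect of replacing the chlorine on the shared core also remains open.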